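Swapping a cyclohexyl amide for a pyridine amide

The source may report more compounds than this note shows. Statements on the series, on what has been measured and on what is new or still open speak of the compounds shown alone.

Measured so far:
compound 1 `O=C(C1CCCCC1)N1CCC(C(=O)N2N=CCC2c2ccccc2)CC1`, 5.4
compound 2 `CC(C)(C)C(=O)N1N=CCC1c1cccc(F)c1`, 5.9
compound 3 `O=C(C1CCOC1)N1N=CCC1c1ccccc1`, 3

In a physicochemical assay for lipophilicity, read by HPLC, measured as chromatographic lipophilicity, at pH 7.4 (a higher number here means a more lipophilic compound, a lower number a more polar compound), compound 1 stands second highest of the three values. Compound 2 lies above it, and compound 3 lies well below it; both gaps are beyond the usual scatter of this assay. Compound 4 `O=C(c1ccccn1)N1CCC(C(=O)N2N=CCC2c2ccccc2)CC1` differs from compound 1 in one place: pyridin-2-yl in place of cyclohexyl on a carbonyl carbon. The change replaces a saturated carbon ring with an aromatic ring that carries a nitrogen able to accept a hydrogen bond, and such a change is expected to lower the number in this assay by a clear step, well beyond the scatter. Compound 4 is therefore expected to give 3.6, between 3 and 4.3, a step of a number 1.80 log units lower from compound 1 to compound 4 (beyond the scatter).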

Compound 4, distribution coefficient: 3.1
Compound 4: the middle estimate sits 0.50 log units above what was measured; low and high end bracket the measured number.
By their numbers in this assay, from the lowest: compounds 3 and 4 (each within the scatter of the next); then compound 1; then compound 2.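

In this assay, among the compounds shown here, putting pyridin-2-yl in place of cyclohexyl on this carbonyl carbon gives a number 2.30 log units lower from compound 1 to compound 4 (beyond the scatter), the only one-place comparison so far. The number at this position is therefore far from indifferent to the group: a ring of the same heavy-atom count, with one hydrogen-bond acceptor added, moves it by a large step. Nothing measured here tells why. Still open, going by these compounds, is whether the step follows the ring nitrogen or the aromatic ring itself: phenyl on the same carbonyl carbon would separate the two, and pyridin-3-yl or pyridin-4-yl would test where the nitrogen stands.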